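A few compounds are considered here, and "the series" means these few. Any claim that something is new, unique, unknown or untested is made for them only; others in the source may bear on it.

Measured compounds:
- compound 1, `COc1ccc2cc([C@@](C)(O)CCN(C)C)ccc2c1`, giving 25 nM in an assay for displacement of a labelled ligand from Sigma non-opioid intracellular receptor 1 (Cavia porcellus), read by scintillation counting, with a stated time of 120 min; a higher number here means a weaker inhibitor, a lower number a stronger inhibitor
- compound 2, `CN(C)CCC(C)(O)c1ccc2ccccc2c1`, giving 77 nM in this assay

Within the data shown here, compound 2 has the higher of the two numbers so far, so it binds more weakly than compound 1; the gap between compound 1 and compound 2 lies beyond the usual scatter of repeated measurements. Compound 3, `CN(C)CC[C@](C)(O)c1ccc2ccccc2c1`, has not yet been measured in this assay. It is built from exactly the same atoms and bonds as compound 2, and the only difference is this: the two compounds have the same atoms and bonds; at least one stereo element is drawn with a configuration in one of them and without one in the other: 1 of 1 stereo elements differ; a stereocentre at a saturated chain carbon is drawn without a configuration in compound 2 and S in compound 3. In other words, compound 2 represents the mixture of both mirror-image forms, while compound 3 is a single one of them. When one mirror-image form is separated from such a mixture, the number can stay about where the mixture stands or move by a modest amount in either direction, depending on which form carries the binding. Among the measured compounds shown here, no measured pair here shows such a step. The expectation is therefore a small step, most likely toward a somewhat lower number, and possibly none beyond the scatter. For compound 3 the estimated value in this assay is 50 nM, within a range from 20 nM to 150 nM, which is expected to mean a step of a 1.5-fold lower number from compound 2 to compound 3 (0.19 log units; within the scatter).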

Compound 3, inhibition constant: 63 nM
The estimate for compound 3 lay 1.3-fold (0.10 log units) below the measured number, within the range that was stated.
By their numbers in this assay, from the lowest: compound 1; then compounds 3 and 2 (each within the scatter of the next).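

In this assay, the S form at this saturated chain carbon cannot be told apart from the mixture, with a 1.2-fold lower number from compound 2 to compound 3 (0.09 log units; within the scatter), and the sole difference behind that step is: the fact that one of compounds 2 and 3 is drawn with a defined configuration and the other without, at the place where they differ

Among these compounds, compound 3 also supplies what the earlier compounds lacked, a partner for compound 1 that differs in one place only, hydrogen in place of methoxy on an aromatic carbon. That comparison gives a 2.5-fold higher number from compound 1 to compound 3 (0.40 log units; beyond the scatter), so the methoxy group can now be tied to stronger binding with no difference in drawn configuration to confuse the reading.

The S form matching the mixture says little about the R form, whose own number would show whether the two mirror-image forms really differ at this carbon. Also open, on these data alone, is whether the gain is particular to methoxy or would carry over to an ethoxy group or a chlorine atom on the same aromatic carbon, and what a longer chain leading to the dimethylamino group would do.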